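Swapping phenyl for benzyl on selenium in a quinoline series

The compounds below may be only part of what the source reports. "The series", "measured", "known", "first", "only" and "open" are said of these compounds alone.

Measured so far:
- compound 1, `CCOC(=O)c1cc([Se]c2ccccc2)c2cc(Br)ccc2n1`: 20800 nM
- compound 2, `CCOC(=O)c1cc(C#Cc2ccc(N)cc2)c2cc(OC)ccc2n1`: 61000 nM

Both compounds were tested in a functional assay on Jurkat cells (Homo sapiens) for cytotoxicity, read by MTT assay, with a stated time of 24 h; on this read-out higher numbers stand for an effect only at larger amounts of compound and lower numbers for an effect already at smaller amounts. Compound 1 gives 20800 nM, the lowest of the two numbers; compound 2 gives 61000 nM, a gap that lies beyond the usual scatter, so compound 1 acts at smaller amounts than compound 2 on this read-out.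

Compound 3, `CCOC(=O)c1cc([Se]Cc2ccccc2)c2cc(Br)ccc2n1`, has not yet been measured in this assay. It keeps the core of compound 1 and differs from it at one place: benzyl in place of phenyl on a selenium. For the measured compounds named here, no measured pair in the set shows what such an exchange does, so any expectation rests on compound 1 alone. A change of this kind is expected to leave the number close to that of compound 1, with the step from compound 1 to compound 3 expected to be a 1.0-fold lower number from compound 1 to compound 3 (0.02 log units; within the scatter), not beyond the scatter. Compound 3 is therefore estimated at 20000 nM, with a range from 7000 nM to 60000 nM.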

Compound 3, half-maximal effective concentration: 53600 nM
The estimate for compound 3 lay 2.7-fold (0.43 log units) below the measured number; the measured number falls inside the stated range.
By their numbers in this assay, from the lowest: compound 1; then compounds 3 and 2 (each within the scatter of the next).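

In this assay, the exchange of phenyl for benzyl on a selenium gives a 2.6-fold higher number from compound 1 to compound 3 (0.41 log units; beyond the scatter) while the rest of the core of compound 1 stays the same. This single-place pair shows that the group on selenium can shift this read-out, even though phenyl and benzyl each carry one six-membered aromatic ring of carbon only and neither has hydrogen-bond donors or acceptors. No measurement at hand accounts for the shift.

The compounds shown leave open whether a longer chain on selenium, such as phenylethyl, would raise the number further, or whether a small methyl group would reverse the trend. One pair also cannot tell whether the same exchange would have a similar effect on a core carrying methoxy rather than bromine.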